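This account rests on a few compounds, and the source may have more. Where it says the series, first, only, none or still open, it means among the compounds named here.

Measured compounds:
compound 1, `Cn1c(SCc2ccc(Br)cc2)nnc1-c1cc([N+](=O)[O-])cc([N+](=O)[O-])c1`: > 30000 nM (a limit)
compound 2, `Cn1c(SCc2ccc(Cl)cc2)nnc1-c1cc([N+](=O)[O-])cc([N+](=O)[O-])c1`: > 30000 nM (a limit)

In an ADME assay on A-431 cells (Homo sapiens) for cytotoxicity, with a stated time of 48 h (a higher number here means a weaker inhibitor, a lower number a stronger inhibitor), compound 1 gives > 30000 nM, which is a limit of the assay and not a number. In this assay compound 2 likewise gives > 30000 nM, again a limit. Compound 2 therefore stands only at that limit; the limit of > 30000 nM in this assay, at which 2 of the 2 values shown sit, holds for both values shown. For the measured compounds named here, the single measured step, a step that the two limits leave unreadable from compound 1 to compound 2, cannot be read from the two limits, so no size is known for it.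

Compound 3, `O=[N+]([O-])c1cc(-c2nnc(SCc3ccc(Cl)cc3)n2Cc2ccccc2)cc([N+](=O)[O-])c1`, differs from compound 2 by phenyl in place of hydrogen on a saturated chain carbon bound to an aromatic nitrogen. Going by the values given here, no measured step concerns a change of this kind; the one step that exists is the unreadable one between the two limits. The only footing is that compound 2 sits at the limit and that nothing shown points either way for the entering phenyl. The estimated step of a number no higher from compound 2 to compound 3 (the limit leaves the size open) is accordingly set at no change beyond the scatter, a formal number only. Compound 3 is estimated at 30000 nM, with a range from 8000 nM to 100000 nM, and is expected most likely to be reported again as a limit.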

Compound 3, half-maximal inhibitory concentration: > 30000 nM
Compound 3 gave a limit, no number (the forecaster's own chance of this, stated with the estimate: 70%); the middle value sits exactly at the limit.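

In this assay compound 3 gives > 30000 nM, a limit of the assay and not a number. For the compounds shown here, compound 2 also stands at a limit, so no step from it to compound 3 can be read. The series rests on one limit: the limit of > 30000 nM in this assay, at which 3 of the 3 values shown sit. The compounds shown leave open how far each lies from that limit.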